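The source may hold more compounds than are shown below. What is called first, only, known or untested is meant among the compounds shown, and "the series" means these compounds.

In a functional assay on KB cells (Homo sapiens) for cytotoxicity, read by spectrophotometry and crystal violet staining (a lower number here means a stronger inhibitor, a higher number a weaker inhibitor), compound 1 `CO/N=C/c1c(Cl)n(C2O[C@H](CO)[C@@H](O)[C@H]2O)c2cc(Cl)c(Cl)cc12` gives 70000 nM and compound 2 `N/C(=N\O)c1c(Br)n(C2O[C@H](CO)[C@@H](O)[C@H]2O)c2cc(Cl)c(Cl)cc12` gives 35000 nM. Among the measured compounds shown here, these two values lie within the scatter of each other, so compound 1 cannot be ranked apart from the only other measured compound. For the measured compounds named here, the two compounds differ in more than one place, and no measured pair isolates a single change.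

Compound 3 `N#Cc1c(Cl)n(C2O[C@H](CO)[C@@H](O)[C@H]2O)c2cc(Cl)c(Cl)cc12` keeps the core of compound 1 and changes one substituent. A cyano group takes the place of a group of 4 heavy atoms, on an aromatic carbon of the five-membered aromatic ring: a group of 2 heavy atoms (1 carbon, 1 nitrogen; no ring) in place of a group of 4 heavy atoms (2 carbon, 1 nitrogen, 1 oxygen; no ring), on an aromatic carbon. The neighbouring chloro group stays in place.

Going by the values given here, with no measured step for this exchange, the expectation rests on the narrow spread of the two known values, with compound 2 at 35000 nM carrying a different group at this place. The estimated step of a 1.8-fold lower number from compound 1 to compound 3 (0.24 log units; within the scatter) is expected to be modest, leaning towards a lower number and not clearly beyond the scatter. For compound 3 the expected value is 40000 nM, with an estimated range from 12000 nM to 100000 nM.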

Compound 3, half-maximal inhibitory concentration: 65000 nM
The estimate for compound 3 lay 1.6-fold (0.21 log units) below the measured number; the measured number falls inside the stated range.
By their numbers in this assay, from the lowest: compounds 2, 3 and 1 (each within the scatter of the next).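

In this assay, placing cyano on this aromatic carbon of the five-membered aromatic ring, a group of 2 heavy atoms in place of a group of 4 heavy atoms, gives a 1.1-fold lower number from compound 1 to compound 3 (0.03 log units; within the scatter), a step within the scatter. Among the compounds shown here, this is the first measured pair that differs in one place only, and it shows that, with the chloro group kept on the neighbouring ring atom, these two groups cannot be told apart in this assay, although cyano has a triple bond and 1 hydrogen-bond acceptor where the leaving group has a double bond and 2 hydrogen-bond acceptors. Nothing available gives a reason for this result.

Compound 2 differs from compound 1 and from compound 3 in more than one place, so its steps to them cannot be read. Going by these compounds, whether an amine, a carboxylic acid or a longer chain on this aromatic carbon would give a number beyond the scatter remains open, as does whether the same exchange would read alike with bromo in place of the chloro group.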